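Fluoro-to-nitro swap on the styryl arm: compound 4

This account rests on a few compounds, and the source may have more. Where it says the series, first, only, none or still open, it means among the compounds named here.

Measured so far in a functional assay on HeLa cells (Homo sapiens) for cytotoxicity, read by WST assay, with a stated time of 48 h; a lower number here means a stronger inhibitor, a higher number a weaker inhibitor:
compound 1 `O[C@@H](c1ccccc1)[C@H]1CO[C@H](c2ccccc2)[C@@H](C/C=C/c2cccc(F)c2)C1` gives 8380 nM
compound 2 `O=[N+]([O-])c1cccc(/C=C/C[C@H]2C[C@@H]([C@@H](O)c3ccccc3)CO[C@@H]2c2ccccc2)c1` gives 7850 nM
compound 3 `O[C@@H](c1ccccc1)[C@H]1CO[C@H](c2ccccc2)[C@@H](C/C=C/c2ccccc2F)C1` gives 9730 nM

Compound 4 `O=[N+]([O-])c1ccccc1/C=C/C[C@H]1C[C@@H]([C@@H](O)c2ccccc2)CO[C@@H]1c1ccccc1` is not yet measured. It differs from compound 3 by nitro in place of fluoro on an aromatic carbon. The same swap has been made once before, from compound 1 to compound 2: nitro in place of fluoro on an aromatic carbon, giving a 1.1-fold lower number from compound 1 to compound 2 (0.03 log units; within the scatter). The two cores differ by 2-fluorophenyl in place of 3-fluorophenyl on a double-bonded chain carbon bound to a double-bonded chain carbon. The two places are not identical: in the earlier pair the swapped group sits meta to a large group, here it sits ortho to a large group, so this is the same kind of change, not the same change. Placed beside the earlier step, the step from compound 3 to compound 4 is expected to be a 1.1-fold lower number from compound 3 to compound 4 (0.04 log units; within the scatter), resting on the flat outcome of a 1.1-fold lower number from compound 1 to compound 2 (0.03 log units; within the scatter) and on compound 3 at 9730 nM. For compound 4 the estimate is 8800 nM, with a range of 4000 nM to 19000 nM.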

Compound 4, half-maximal inhibitory concentration: 11800 nM
For compound 4 the middle estimate is 1.3-fold (0.13 log units) below the measured one; the range from low to high includes it.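

In this assay, nitro in place of fluoro on an aromatic carbon gives a 1.2-fold higher number from compound 3 to compound 4 (0.08 log units; within the scatter), and the swap carries from one core to the other with no difference between the two steps that can be told from noise: the same change on two cores in this assay, a 1.1-fold lower number (0.03 log units; within the scatter) from compound 1 to compound 2 and a 1.2-fold higher number (0.08 log units; within the scatter) from compound 3 to compound 4, 1.3-fold (0.11 log units) apart, within the scatter of two such steps. 2-nitrophenyl in place of 3-nitrophenyl gives a 1.5-fold higher number from compound 2 to compound 4 (0.18 log units; within the scatter) and 2-nitrophenyl in place of 3-fluorophenyl gives a 1.4-fold higher number from compound 1 to compound 4 (0.15 log units; within the scatter), so these changes are flat as well. This shows that the swap is silent on these two cores, but it does not show an effect of either group or of its place, and two pairs set no rule for other cores.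

On these data alone, whether an amine or a carboxylic acid on the same aromatic ring, or a longer chain in place of the alkene arm, would move the number beyond the scatter remains open.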